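The source may hold more compounds than are shown below. What is called first, only, known or untested is meant among the compounds shown, and "the series" means these compounds.

Measured compounds:
compound 1 `COc1ccccc1N1CCN(C(=O)CCc2c(-c3ccc(Cl)cc3)[nH]c3cccc(Cl)c23)CC1` with 950 nM
compound 2 `COc1ccccc1N1CCN(C(=O)CCc2c(-c3ccc(Cl)cc3)[nH]c3c(Cl)cc(Cl)cc23)CC1` with 14 nM

In an assay on CHO cells for displacement of a labelled ligand from Substance-P receptor (Homo sapiens) (on this read-out lower numbers stand for stronger inhibition and higher numbers for weaker inhibition), compound 1 gives 950 nM, the highest of the two numbers and therefore the weaker binder of the pair. Among the measured compounds shown here, compound 2 carries two chloro groups on its fused ring system in place of the single chloro group of compound 1; in this assay compound 2 gives 14 nM, a far lower number that lies well beyond the usual scatter.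

Compound 3 `COc1ccccc1N1CCN(C(=O)CCc2c(-c3ccc(Cl)cc3)[nH]c3cc(Cl)cc(Cl)c23)CC1` has not yet been measured in this assay. It differs from compound 1 by chloro in place of hydrogen on an aromatic carbon. For the measured compounds named here, it thus keeps the chloro group of compound 1 and adds a second one, in a pattern that is not the one found in compound 2.

Without a measured step of exactly this kind, the expectation rests on the two values shown. Because compound 2 gives 14 nM, a second chloro group on the fused ring system appears to be well tolerated and may lower the number considerably. Compound 3 is therefore expected to show a step of a 14-fold lower number from compound 1 to compound 3 (1.13 log units; beyond the scatter) from compound 1, towards stronger binding. For compound 3 the estimate in this assay is 70 nM, within a range of 15 nM to 350 nM.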

Compound 3, half-maximal inhibitory concentration: 570 nM
Compound 3: middle estimate off by 8.1-fold (0.91 log units), on the low side; the measured number lies above the stated range.
By their numbers in this assay, from the lowest: compound 2; then compounds 3 and 1 (each within the scatter of the next).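

In this assay, putting a chloro group on this aromatic carbon, meta to the existing chloro group and para to a fused ring, gives a 1.7-fold lower number from compound 1 to compound 3 (0.22 log units; within the scatter), a step too small to tell apart from no difference at all. Among the compounds shown here, this is the first single-place change in the set, and it shows that adding a second chloro group to the core of compound 1 does not necessarily bring a large step, so a second chloro group alone cannot account for the low number of compound 2 at 14 nM, which differs from compound 1 in more than one place. No measurement here bears on what lies behind this result.

Going by these compounds, it remains open whether a different group on this same carbon, such as fluoro, a nitrile or an amine, would give a step beyond the scatter. The compounds shown also leave open what a single chloro group contributes on each of the other aromatic carbons of the shared core, including those that carry chloro in compound 2.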